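This account rests on a few compounds, and the source may have more. Where it says the series, first, only, none or still open, it means among the compounds named here.

Measured compounds in a functional assay on NCI-H322M cells (Homo sapiens) for inhibition, read by sulforhodamine B assay, with a stated time of 48 h; a higher number here means a weaker inhibitor of growth, a lower number a stronger inhibitor of growth:

- compound 1 `COc1cc(-c2cc(/C=C/C(=O)c3ccc(N)cc3)[nH]n2)cc(OC)c1OC` gives 2230 nM
- compound 2 `COc1ccc(-c2cc(/C=C/C(=O)c3ccc(N)cc3)[nH]n2)cc1OC` gives 4340 nM
- compound 3 `COc1cc(C(=O)/C=C/c2cc(-c3cc(OC)c(OC)c(OC)c3)n[nH]2)cc(OC)c1OC` gives 2000 nM

Compound 1 stands second highest of the three numbers. Its nearest neighbour is compound 3, which sits within the scatter of it; its furthest is compound 2, and even that gap, a 1.9-fold higher number from compound 1 to compound 2 (0.29 log units; within the scatter), is within the scatter. So the three measured compounds give no distinction that can be read as real.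

Compound 4 `COc1cc(-c2cc(/C=C/C(=O)c3ccc(F)c(F)c3)[nH]n2)cc(OC)c1OC` differs from compound 1 in one place: 3,4-difluorophenyl in place of 4-aminophenyl on a carbonyl carbon. Within the data shown here, the only measured step concerns hydrogen in place of methoxy on an aromatic carbon, and it was within the scatter; no measured step touches the group on the carbonyl carbon. There is therefore nothing in the data that points either way for this change, and the default expectation is no step beyond the scatter: the estimated step is a 1.1-fold higher number from compound 1 to compound 4 (0.05 log units; within the scatter). As far as these compounds go, compound 4 is expected to give about 2500 nM in this assay, with a range of 700 nM to 9000 nM, kept wide since the change is untested here.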

Compound 4, concentration for 50% growth inhibition: 3370 nM
For compound 4 the middle estimate is 1.3-fold (0.13 log units) below the measured one; the measured number falls inside the stated range.
By their numbers in this assay, from the lowest: compounds 3, 1, 4 and 2 (each within the scatter of the next, the first and the last beyond it).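

Among these compounds, at the carbonyl carbon, 3,4-difluorophenyl in place of 4-aminophenyl gives a 1.5-fold higher number from compound 1 to compound 4 (0.18 log units; within the scatter) in this assay and is the only measured step at this position. The two groups are not told apart here, even though 4-aminophenyl carries a hydrogen-bond donor and acceptor and 3,4-difluorophenyl carries neither. Within this single pair, the amine is therefore not needed to keep growth inhibition in the same range, and no available evidence bears on why the two groups read alike.

As far as these compounds go, whether a carboxylic acid or an unsubstituted phenyl on the carbonyl carbon would give a step beyond the scatter remains open. From the compounds shown here alone, it is also open whether 3,4-difluorophenyl would read the same on the core of compound 2 as on the core of compound 1.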